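The compounds below may be only part of what the source reports. "The series", "measured", "known", "first", "only" and "open" are said of these compounds alone.

Measured so far, in a functional assay on A375P cells (Homo sapiens) for antiproliferative activity, read by MTT assay, with a stated time of 48 h; on this read-out lower numbers stand for stronger inhibition and higher numbers for weaker inhibition:
Compound 1 `COc1ccc(C(=O)Nc2cccc(-c3ccnc4c(N)cccc34)c2)cc1OC` gives 9500 nM.
Compound 2 `Cc1ccc(C(=O)Nc2cccc(-c3ccnc4c(N)cccc34)c2)cc1C` reaches only a limit of the assay, > 20000 nM.
Compound 3 `COc1ccc(C(=O)Nc2cccc(-c3ccnc4c(NC(C)=O)cccc34)c2)cc1OC` gives 5300 nM.

Among the two real numbers, compound 3 gives the lower one, but its nearest neighbour is compound 1 and the step of a 1.8-fold lower number from compound 1 to compound 3 (0.25 log units; within the scatter) lies within the scatter, so no order between the two can be claimed. Compound 4 `CC(=O)Nc1cccc2c(-c3cccc(NC(=O)c4ccc(C)c(C)c4)c3)ccnc12` has not been measured. Compared with compound 3 it shows one change: 3,4-dimethylphenyl in place of 3,4-dimethoxyphenyl on a carbonyl carbon. The same exchange has been made once before, on the pair without the acetyl group: an at least 2.1-fold higher number from compound 1 to compound 2 (0.32 log units; beyond the scatter). Compound 2 sat at the limit of > 20000 nM in this assay, at which 1 of the 3 values shown sits, so that step is known only as a lower bound. Carrying the same exchange onto compound 3, the expectation is a weaker compound, with the number in this assay rising by at least a modest amount and possibly reaching the limit again. Compound 4 is therefore estimated at 15000 nM, with a likely range from 7000 nM to 40000 nM. The step this estimate implies, a 2.8-fold higher number from compound 3 to compound 4 (0.45 log units; beyond the scatter), is expected to lie beyond the scatter.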

Compound 4, half-maximal inhibitory concentration: > 20000 nM
Compound 4 was reported as a limit; the forecaster's own chance of this, stated with the estimate: 45%; middle value at least 1.3-fold (0.12 log units) from the limit.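

In this assay, the loss seen earlier without the acetyl group appears on the acetylated core too: 3,4-dimethylphenyl in place of 3,4-dimethoxyphenyl on a carbonyl carbon gives an at least 3.7-fold higher number from compound 3 to compound 4 (0.57 log units; beyond the scatter). Compound 4 reaches only a limit of the assay, > 20000 nM. The loss on this change is therefore no longer tied to a single core, though its size on each stays unsettled: the same change on two cores in this assay, an at least 2.1-fold higher number (0.32 log units; beyond the scatter) from compound 1 to compound 2 and an at least 3.7-fold higher number (0.57 log units; beyond the scatter) from compound 3 to compound 4; the limit leaves it open whether they differ

As far as these compounds go, the step between compound 2 and compound 4 cannot be read, so the effect of the acetyl group with 3,4-dimethylphenyl in place stays unknown, since both values are limits: the limit of > 20000 nM in this assay, at which 2 of the 4 values shown sit. Also open is how a phenyl ring carrying a single methoxy group, two hydroxy groups or an amine would behave on that carbonyl carbon.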